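This account rests on a few compounds, and the source may have more. Where it says the series, first, only, none or still open, it means among the compounds named here.

Working notes on the series, measured in a functional assay on MCF7 cells (Homo sapiens) for antiproliferative activity, read by MTT assay, with a stated time of 72 h; a lower number here means a stronger inhibitor, a higher number a weaker inhibitor:

- compound 1 `CCn1c(C(=O)NCC(=O)O)ccc1C(CC)(CC)c1ccc(C#CC(O)(CC)CC)c(C)c1`: 5140 nM
- compound 2 `CCn1c(C(=O)NCCC(=O)O)ccc1C(CC)(CC)c1ccc(C#CC(O)(CC)CC)c(C)c1`: > 50000 nM (a limit of the assay, not a number)
- compound 3 `CCN(CC)CCNC(=O)c1cc(C(CC)(CC)c2ccc(C#CC(O)(CC)CC)c(C)c2)cn1CC`: 1800 nM

Compound 3 has the lower of the two actual numbers, and compound 1, at 5140 nM, lies higher by a gap beyond the scatter. Compound 2 reports only a limit, as recorded in the limit of > 50000 nM in this assay, at which 1 of the 3 values shown sits.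

The next compound to be measured is compound 4 `CCn1cc(C(CC)(CC)c2ccc(C#CC(O)(CC)CC)c(C)c2)cc1C(=O)N[C@@H](C(=O)O)C(C)C`. It keeps the core of compound 3 and changes the amide side chain: 1-carboxy-2-methylpropyl in place of 2-(diethylamino)ethyl on an amide-type nitrogen. In short, 1-carboxy-2-methylpropyl stands in place of 2-(diethylamino)ethyl on an amide-type nitrogen.

Among the measured compounds shown here, no measured step covers this exchange directly. For the measured compounds named here, the one measured step is an at least 9.7-fold higher number from compound 1 to compound 2 (0.98 log units; beyond the scatter), which is beyond the scatter and shows that this assay can respond strongly to a small change among carboxy-bearing chains. The closest guide is compound 1, whose amide chain also carries carboxy and which gives 5140 nM. On that basis, a moderate move to a higher number is expected, with wide uncertainty. The expected size is a 4.4-fold higher number from compound 3 to compound 4 (0.65 log units; beyond the scatter). For compound 4 the estimated value is 8000 nM, with an expected range of 2000 nM to 35000 nM.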

Compound 4, half-maximal inhibitory concentration: 18000 nM
Compound 4: the middle estimate sits 2.3-fold (0.35 log units) below what was measured; measured number inside the range.
By their numbers in this assay, from the lowest: compound 3; then compound 1; then compound 4. At a limit, above all of these: compound 2.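

Among the compounds shown here, with the core held fixed, 1-carboxy-2-methylpropyl in place of 2-(diethylamino)ethyl on the amide-type nitrogen gives, in this assay, a 10-fold higher number from compound 3 to compound 4 (1.00 log units; beyond the scatter), the first direct reading of this exchange. Compound 1 and compound 3 differ in more than one place and offered no such reading; here the amide side chain alone changes, and the result at this position lies beyond the scatter. Nothing measured in the series gives a cause for this step.

The exchange alters the whole chain at once, so the compounds shown do not separate the loss of the diethylamino group from the gain of the carboxy group or from the branching and the defined stereocentre of the new chain. The methyl ester of the 1-carboxy-2-methylpropyl chain, an unbranched chain ending in a carboxylic acid on this same core, and a 2-(dimethylamino)ethyl chain would each bear on that question, as would the opposite configuration at the stereocentre.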